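A Dimethylaminomethyl Analogue of Compound 1 Under Consideration

The source may report more compounds than this note shows. Statements on the series, on what has been measured and on what is new or still open speak of the compounds shown alone.

Measured compounds:
compound 1, `O=C(NCc1ccc(F)cc1)c1cccc(O)c1O`, > 40000 nM
compound 2, `O=C(NCc1ccc(F)cc1)c1cc(S(=O)(=O)N2CCCCC2)cc(O)c1O`, 13000 nM

Compound 1 was assessed in an ADME assay on NCI-H630 cells (Homo sapiens) for cytotoxicity, read by MTT assay, with a stated time of 72 h; on this read-out lower numbers stand for higher toxicity in this test and higher numbers for lower toxicity in this test. For compound 1 the reading of > 40000 nM is a limit of the assay rather than a number, so compound 1 stands only at a bound (the limit of > 40000 nM in this assay, at which 1 of the 2 values shown sits). Compound 2, carrying a (piperidin-1-yl)sulfonyl group in place of hydrogen on an aromatic carbon, gives 13000 nM in this assay, and the step of an at least 3.0-fold lower number from compound 1 to compound 2 (0.48 log units; beyond the scatter) lies beyond the scatter.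

Compound 3, `CN(C)Cc1ccc(C(=O)NCc2ccc(F)cc2)c(O)c1O`, differs from compound 1 by (dimethylamino)methyl in place of hydrogen on an aromatic carbon. Within the data shown here, only the step from compound 1 to compound 2 bears on this change, and it concerns a different group on a different aromatic carbon, so its guidance is indirect. A lower number than the limit of compound 1 is expected, of smaller or similar size. Compound 3 is therefore estimated at 25000 nM, within 8000 nM to 60000 nM, corresponding to an expected step of an at least 1.6-fold lower number from compound 1 to compound 3 (0.20 log units; that floor lies within the scatter).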

Compound 3, half-maximal cytotoxic concentration: > 10000 nM
Compound 3: a limit, no number; the forecaster's own chance of this, stated with the estimate: 40%; the middle value lies beyond the limit too.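

In this assay compound 3 gives > 10000 nM, a limit and not a number. Among these compounds, compound 1 gives > 40000 nM, also a limit, so no step to compound 3 can be read. The compounds shown leave open whether (dimethylamino)methyl in place of hydrogen on an aromatic carbon shifts the number at all.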